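Amide aryl substituents and growth inhibition in the series

The source may report more compounds than this note shows. Statements on the series, on what has been measured and on what is new or still open speak of the compounds shown alone.

Compound 1 `COc1cc(-c2nn(-c3cccc(NC(=O)c4cccc(C(F)(F)F)c4)c3)cc2-c2ccncc2)ccc1Cl` in a functional assay on IGROV-1 cells (Homo sapiens) for inhibition, read by sulforhodamine B assay, with a stated time of 48 h (a lower number here means a stronger inhibitor of growth, a higher number a weaker inhibitor of growth), gives 1830 nM. Compound 2 `COc1cc(-c2nn(-c3cccc(NC(=O)c4ccc(Cl)c(C(F)(F)F)c4)c3)cc2-c2ccncc2)ccc1Cl`, differing by chloro in place of hydrogen on an aromatic carbon, in this assay gives 2150 nM; the step of a 1.2-fold higher number from compound 1 to compound 2 (0.07 log units; within the scatter) shows the two values lying within the scatter of each other, so the added chloro brings no detectable shift on the shared core. Compound 3 `COc1cc(-c2nn(-c3cccc(NC(=O)c4ccccc4)c3)cc2-c2ccncc2)ccc1Cl` differs from compound 2 by phenyl in place of 4-chloro-3-(trifluoromethyl)phenyl on a carbonyl carbon. Among the measured compounds shown here, the only measured step, a 1.2-fold higher number from compound 1 to compound 2 (0.07 log units; within the scatter), bears on the chloro part of this change and was within the scatter; no measured step covers the loss of the trifluoromethyl group, so that part of the change is uncertain. Compound 3 is therefore expected to show a step of a 1.1-fold higher number from compound 2 to compound 3 (0.05 log units; within the scatter) not clearly beyond the scatter, with a wide range kept. The estimate for compound 3 in this assay is 2400 nM, expected within 800 nM to 7500 nM.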

Compound 3, concentration for 50% growth inhibition: 534 nM
Beside the measured number, compound 3's estimate is 4.5-fold (0.65 log units) above it, and the stated range ends above it.
By their numbers in this assay, from the lowest: compound 3; then compounds 1 and 2 (each within the scatter of the next).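

In this assay, the unsubstituted phenyl on the carbonyl carbon gives the lowest number of the three compounds: phenyl in place of 4-chloro-3-(trifluoromethyl)phenyl is a 4.0-fold lower number from compound 2 to compound 3 (0.60 log units; beyond the scatter), and hydrogen in place of trifluoromethyl alone is a 3.4-fold lower number from compound 1 to compound 3 (0.53 log units; beyond the scatter). Set against the chloro step, a 1.2-fold higher number from compound 1 to compound 2 (0.07 log units; within the scatter), which stays within the scatter, the measured change at this aryl group goes with the trifluoromethyl group and not with the chloro, so neither substituted compound here improves on plain phenyl. No measurement on hand accounts for this shift.

Still open, on these data alone, is whether any group on this phenyl lowers the number further, for instance an amine, a carboxylic acid or a methoxy group. Also open, as far as these compounds go, is whether chloro alone, without trifluoromethyl, stays within the scatter of compound 3.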